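Swapping the aryl on the hydrazone carbon for 4-chlorophenyl

The compounds below may be only part of what the source reports. "The series", "measured", "known", "first", "only" and "open" are said of these compounds alone.

Measured so far:
compound 1 `CN(C)CCn1cnnc1-c1cc(Oc2ccc(NC(=O)N/N=C/c3ccc(O)c(Br)c3)cc2F)ccn1` — 450 nM
compound 2 `CN(C)CCn1cnnc1-c1cc(Oc2ccc(NC(=O)N/N=C/c3ccc(F)cc3F)cc2F)ccn1` — 960 nM
compound 3 `CN(C)CCn1cnnc1-c1cc(Oc2ccc(NC(=O)N/N=C/c3c(O)ccc4ccccc34)cc2F)ccn1` — 670 nM

In a functional assay on HT-29 cells (Homo sapiens) for cytotoxicity, read by MTT assay, with a stated time of 72 h (a higher number here means a weaker inhibitor, a lower number a stronger inhibitor), compound 3 gives 670 nM. Compound 3 sits second highest of the three numbers; the step of a 1.4-fold lower number from compound 2 to compound 3 (0.16 log units; within the scatter) and the step of a 1.5-fold higher number from compound 1 to compound 3 (0.17 log units; within the scatter) both lie within the scatter, so all three compounds lie within the scatter of one another. Compound 4 `CN(C)CCn1cnnc1-c1cc(Oc2ccc(NC(=O)N/N=C/c3ccc(Cl)cc3)cc2F)ccn1` differs from compound 3 only at the hydrazone carbon: 4-chlorophenyl in place of 2-hydroxynaphthalen-1-yl on a carbon with a double bond to nitrogen. Among the measured compounds shown here, the steps that bear on this position are a 2.1-fold higher number from compound 1 to compound 2 (0.33 log units; beyond the scatter), a 1.5-fold higher number from compound 1 to compound 3 (0.17 log units; within the scatter) and a 1.4-fold lower number from compound 2 to compound 3 (0.16 log units; within the scatter); only the first is beyond the scatter, and it moved the number up. Since compound 4, like compound 2, carries no hydrogen-bond donor or acceptor on the entering group, a number near that of compound 2 is expected, which means an expected step of a 1.3-fold higher number from compound 3 to compound 4 (0.10 log units; within the scatter), not clearly beyond the scatter. Compound 4 is therefore estimated at 850 nM in this assay, with a range from 400 nM to 1800 nM.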

Compound 4, half-maximal inhibitory concentration: 530 nM
For compound 4 the middle estimate is 1.6-fold (0.21 log units) above the measured one; the range from low to high includes it.
By their numbers in this assay, from the lowest: compounds 1, 4, 3 and 2 (each within the scatter of the next, the first and the last beyond it).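

In this assay, 4-chlorophenyl, with 0 hydrogen-bond donors and 0 hydrogen-bond acceptors, can replace 2-hydroxynaphthalen-1-yl and leave the result within the scatter (a 1.3-fold lower number from compound 3 to compound 4 (0.10 log units; within the scatter)). Among the compounds shown here, the same holds against the other two aryl groups (a 1.8-fold lower number from compound 2 to compound 4 (0.26 log units; within the scatter); a 1.2-fold higher number from compound 1 to compound 4 (0.07 log units; within the scatter)), so the one step beyond the scatter among the earlier compounds does not extend to every aryl group without a hydroxyl: compound 4 stays within the scatter of both hydroxyl-bearing compounds. No measurement here accounts for these results.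

The aryl groups shown carry only halogens and hydroxyl, so the effect of an amine or a carboxylic acid on the aryl group remains open. As far as these compounds go, whether an unsubstituted phenyl or an alkyl chain on the hydrazone carbon would stay within this narrow spread is also open.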